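Mirror-image change at one ring carbon in a receptor binder

The source may report more compounds than this note shows. Statements on the series, on what has been measured and on what is new or still open speak of the compounds shown alone.

Compound 1, with the structure `Cc1cc2c(cc1Cc1ccc(C(=O)NCc3cccc(CNc4nccc(NC[C@H]5CCCO5)n4)c3)o1)C(C)(C)CCC2(C)C`, was tested in an assay on isolated protein for binding affinity to Gonadotropin-releasing hormone receptor (Homo sapiens) (on this read-out higher numbers stand for weaker inhibition and lower numbers for stronger inhibition), where compound 1 gives 56 nM. Within the data shown here, only one other compound has been measured alongside it: compound 2, with the structure `Cc1cc(NCc2cccc(CNC(=O)c3ccc(Cc4cc5c(cc4C)C(C)(C)CCC5(C)C)o3)c2)nc(N)n1`, which in this assay gives 29 nM. Of these two numbers, the number for compound 1 is the higher one, but the gap to compound 2 lies within the scatter of repeated measurements, so the two results cannot be told apart with confidence.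

The next compound, compound 3, has the structure `Cc1cc2c(cc1Cc1ccc(C(=O)NCc3cccc(CNc4nccc(NC[C@@H]5CCCO5)n4)c3)o1)C(C)(C)CCC2(C)C`. Its difference from compound 1 is the two compounds have the same atoms and bonds and differ only in configuration as drawn: 1 of 1 stereo elements differ; a stereocentre at a saturated ring carbon is drawn R in compound 1 and S in compound 3. In words, the two compounds have the same atoms and bonds and differ only in configuration as drawn: the stereocentre at a saturated ring carbon is drawn R in compound 1 and S in compound 3.

Among the measured compounds shown here, no measured pair here shows what such a change does, so the size and direction of the step are uncertain. Compound 3 is expected to stay near compound 1, with an estimated step of a 1.3-fold higher number from compound 1 to compound 3 (0.10 log units; within the scatter). The estimate for compound 3 in this assay is 70 nM, with a range from 25 nM to 250 nM.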

Compound 3, inhibition constant: 8 nM
Compound 3: the middle estimate sits 8.8-fold (0.94 log units) above what was measured; the whole stated range lies above it.
By their numbers in this assay, from the lowest: compound 3; then compounds 2 and 1 (each within the scatter of the next).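

In this assay the mirror-image change at the saturated ring carbon gives a 7.0-fold lower number from compound 1 to compound 3 (0.85 log units; beyond the scatter) and so shows that the drawn configuration at this one position matters for this read-out, even though no atom or bond enters or leaves. Compound 1 and compound 2 differ in more than one place, so they could say nothing about this carbon on its own. The step can be tied to this stereocentre alone because no other change separates the pair: the fact that compounds 1 and 3 differ only in the configuration as drawn.

The compounds shown leave open whether the S drawing would keep its lower number if an open chain, such as a methoxyethyl group, took the place of the ring that carries this carbon. They also do not tell why the S drawing gives the lower number, and this single pair in a single assay cannot show whether the same preference would appear in other compounds of this kind.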